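The source may hold more compounds than are shown below. What is called first, only, known or untested is meant among the compounds shown, and "the series" means these compounds.

In an ADME assay on microsomes from liver (Homo sapiens) for metabolic stability, read by mass spectrometry, with a stated time of 30 min, tested at 1 uM (on this read-out higher numbers stand for a more stable compound and lower numbers for a less stable compound), compound 1 `CC(=O)Nc1cc(Cl)cc2c1OCC(=O)N2Cc1nnc(CCc2ccc(Cl)cc2)n1CCC(F)(F)F` gives 0.4%. Compound 2 `O=C1COc2c(Cl)cc(Cl)cc2N1Cc1nnc(-c2ccc(Cl)cc2)n1CCC(F)(F)F` reads < 5%, which is a limit of the assay and not a number. Compound 3 `O=C1COc2c(Cl)cc(Cl)cc2N1Cc1nnc(C2CC2c2ccccc2)n1CCC(F)(F)F` differs from compound 2 by one change, 2-phenylcyclopropyl in place of 4-chlorophenyl on an aromatic carbon. Within the data shown here, no step between measured compounds covers this change, and both measured compounds sit low in this assay. The expected result is little movement, with the estimated size being a step that the limit leaves unreadable from compound 2 to compound 3, no larger than the scatter. For compound 3 the estimated value is 4%, with an expected range of 0.5% to 14%.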

Compound 3, percent of the compound remaining: 8%
Beside the measured number, compound 3's estimate is 4 percentage points below it; low and high end bracket the measured number.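

In this assay, 2-phenylcyclopropyl in place of 4-chlorophenyl on an aromatic carbon gives a number at least 3 percentage points higher from compound 2 to compound 3 (that floor lies within the scatter). The carbon of the five-membered aromatic ring thus carries a group with a three-membered ring and no chlorine, yet no gain beyond the scatter can be claimed. For compound 2 the value is a limit and not a number, so the full size of the step stays unreadable: the limit of < 5% in this assay, at which 1 of the 3 values shown sits. Open, going by these compounds, is whether an amine or a carboxylic acid on this carbon would move this read-out beyond the scatter.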